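Bromo in Place of Methyl on the Pendant Phenyl Ring

A few compounds are considered here, and "the series" means these few. Any claim that something is new, unique, unknown or untested is made for them only; others in the source may bear on it.

Measured compounds:
Compound 1 `O=[N+]([O-])c1ccc(N/C(=N\O)c2ccccc2)c2nonc12`: 268 nM
Compound 2 `O=[N+]([O-])c1ccc(N/C(=N\O)c2ccccc2Br)c2nonc12`: 80 nM
Compound 3 `Cc1cccc(/C(=N/O)Nc2ccc([N+](=O)[O-])c3nonc23)c1`: 163 nM

All three compounds share one core and were tested in an assay on isolated protein for inhibition of Indoleamine 2,3-dioxygenase 1 (Homo sapiens), read by spectrophotometry, with a stated time of 1 h; on this read-out lower numbers stand for stronger inhibition and higher numbers for weaker inhibition. Compound 3 holds the second-highest number of the three. Its nearest neighbour is compound 1, whose value lies within the scatter of it, so no order between these two can be stated. The step of a 2.0-fold higher number from compound 2 to compound 3 (0.31 log units; beyond the scatter) is beyond the scatter, so compound 2 sits clearly below compound 3 on this read-out.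

Compound 4 `O=[N+]([O-])c1ccc(N/C(=N\O)c2cccc(Br)c2)c2nonc12` has not yet been measured in this assay. It differs from compound 3 by bromo in place of methyl on an aromatic carbon. Among the compounds with values here, two measured steps bear on this change. When bromo replaced hydrogen, the number fell: a 3.4-fold lower number from compound 1 to compound 2 (0.53 log units; beyond the scatter). When methyl replaced hydrogen, the change stayed within the scatter: a 1.6-fold lower number from compound 1 to compound 3 (0.22 log units; within the scatter). Within the data shown here, no measured step exchanges methyl for bromo directly, so the comparison is indirect. Since bromo brought a clear lowering in compound 2 and methyl brought none beyond the scatter in compound 3, a modest lowering is expected for compound 4, a 1.5-fold lower number from compound 3 to compound 4 (0.17 log units; within the scatter). Compound 4 is therefore estimated at 110 nM in this assay, with a range from 55 nM to 220 nM.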

Compound 4, half-maximal inhibitory concentration: 105 nM
Estimate against measurement, compound 4: 1.0-fold (0.02 log units) above; the range from low to high includes it.
By their numbers in this assay, from the lowest: compounds 2, 4, 3 and 1 (each within the scatter of the next, the first and the last beyond it).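

In this assay, bromo in place of hydrogen on an aromatic carbon meta to a large group gives a step beyond the scatter (a 2.6-fold lower number from compound 1 to compound 4 (0.41 log units; beyond the scatter)), so a clear lowering from the unsubstituted phenyl ring now appears with 3-bromophenyl as well as with 2-bromophenyl. Neither of the other two exchanges separates its pair: the change from 2-bromophenyl to 3-bromophenyl (a 1.3-fold higher number from compound 2 to compound 4 (0.12 log units; within the scatter)) and the exchange of methyl for bromo at this place (a 1.6-fold lower number from compound 3 to compound 4 (0.19 log units; within the scatter)) both stay within the scatter, so compound 4 cannot be ordered against compound 2 or compound 3, even though only bromo, and not methyl, stands clear of hydrogen. No measurement at hand accounts for any of these steps.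

The compounds shown leave open how an amine, a carboxylic acid or a longer chain would read at this same place, and whether chloro or iodo would fall with bromo. They also hold no methyl at the place bromo takes in compound 2, so the exchange of methyl for bromo can be read at one place only.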